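A few compounds are considered here, and "the series" means these few. Any claim that something is new, unique, unknown or untested is made for them only; others in the source may bear on it.

Three compounds share one core and differ only in the aryl group that sits on the amine nitrogen. Compound 1 `C=C1[C@@H](OC(C)=O)C[C@@H]2[C@](C)(CO[Si](C)(C)C(C)(C)C)[C@H](OC(C)=O)CC[C@@]2(C)[C@@H]1C[C@@H](Nc1ccc(C(=O)O)cc1)C1=CCOC1=O` carries a carboxy group on an aromatic carbon, compound 2 `C=C1[C@@H](OC(C)=O)C[C@@H]2[C@](C)(CO[Si](C)(C)C(C)(C)C)[C@H](OC(C)=O)CC[C@@]2(C)[C@@H]1C[C@@H](Nc1ccc(F)cc1)C1=CCOC1=O` a fluoro group and compound 3 `C=C1[C@@H](OC(C)=O)C[C@@H]2[C@](C)(CO[Si](C)(C)C(C)(C)C)[C@H](OC(C)=O)CC[C@@]2(C)[C@@H]1C[C@@H](Nc1ccc(Br)cc1)C1=CCOC1=O` a bromo group. In a functional assay on HT-29 cells (Homo sapiens) for cytotoxicity, read by sulforhodamine B assay (a higher number here means a weaker inhibitor, a lower number a stronger inhibitor), compound 1 gives 4630 nM, compound 2 gives 4940 nM and compound 3 gives 4590 nM. The measured steps are all small: a 1.1-fold higher number from compound 1 to compound 2 (0.03 log units; within the scatter), a 1.0-fold lower number from compound 1 to compound 3 (0.00 log units; within the scatter) and a 1.1-fold lower number from compound 2 to compound 3 (0.03 log units; within the scatter). Of the three numbers, that of compound 3 is the lowest, yet its steps to both others lie within the scatter, so the three compounds are not separated.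

Compound 4 `C=C1[C@@H](OC(C)=O)C[C@@H]2[C@](C)(CO[Si](C)(C)C(C)(C)C)[C@H](OC(C)=O)CC[C@@]2(C)[C@@H]1C[C@@H](Nc1cccc(OC)c1)C1=CCOC1=O` is the next member. Its change from compound 3 is 3-methoxyphenyl in place of 4-bromophenyl on an amine nitrogen

Going by the values given here, the steps that bear on it are those in which the group on an aromatic carbon was exchanged, a 1.0-fold lower number from compound 1 to compound 3 (0.00 log units; within the scatter) and a 1.1-fold lower number from compound 2 to compound 3 (0.03 log units; within the scatter), both within the scatter. Since those exchanges left the number where it stood, and the present change again exchanges one aryl group for another on the amine nitrogen, no step beyond the scatter is expected in this assay for compound 4, and the step expected is a 1.0-fold higher number from compound 3 to compound 4 (0.00 log units; within the scatter). Compound 4 is therefore estimated at 4600 nM, within a range from 2300 nM to 9200 nM.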

Compound 4, half-maximal inhibitory concentration: > 50000 nM
Compound 4 gave a limit, no number; the forecaster's own chance of this, stated with the estimate: 5%; middle value at least 10-fold (1.03 log units) from the limit.
By their numbers in this assay, from the lowest: compounds 3, 1 and 2 (each within the scatter of the next). At a limit, above all of these: compound 4.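

In this assay, the aryl group on the amine nitrogen turns out not to be indifferent: 3-methoxyphenyl in place of 4-bromophenyl gives an at least 10-fold higher number from compound 3 to compound 4 (1.03 log units; beyond the scatter), and the same change measured against the other two aryl groups gives an at least 10-fold higher number from compound 2 to compound 4 (1.00 log units; beyond the scatter) and an at least 10-fold higher number from compound 1 to compound 4 (1.03 log units; beyond the scatter). The exchanges among 4-carboxyphenyl, 4-fluorophenyl and 4-bromophenyl had left the compounds unseparated, so the flat picture they gave holds for those three groups only and does not extend to every aryl group at this place. Compound 4 stands at a limit of the assay and has no number, so these steps give only the least size of the change: the limit of > 50000 nM in this assay, at which 1 of the 4 values shown sits.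

The change in compound 4 replaces both the substituent and the numbered place it occupies on the phenyl ring, so the compounds shown leave open which of the two goes with the loss, a question that a 4-methoxyphenyl or a 3-bromophenyl group on the amine nitrogen would address. They also leave open whether a group such as an amine or a longer alkoxy chain on the phenyl ring would keep the values of compounds 1, 2 and 3 or follow compound 4.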